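Compound 2 to compound 4 at the assay limit

The source may hold more compounds than are shown below. What is called first, only, known or untested is meant among the compounds shown, and "the series" means these compounds.

In a functional assay on MCF7 cells (Homo sapiens) for antiproliferative activity, read by CCK-8 assay, with a stated time of 48 h (on this read-out higher numbers stand for weaker inhibition and lower numbers for stronger inhibition), compound 2 `C=C(C)C(=O)NCCOc1ccc(Oc2c(-c3ccc(F)cc3)sc3cc(O)ccc23)cc1` gives > 25000 nM as a limit, not a number. Compound 1 `CNC(=O)/C=C/CN1CC(Oc2ccc(Oc3c(-c4ccc(F)cc4)sc4cc(O)ccc34)cc2)C1` gives > 25000 nM as a limit too. Compound 3 `C=C(C)C(=O)N1CC(Oc2ccc(Oc3c(-c4ccc(F)cc4)sc4cc(O)ccc34)cc2)C1` gives > 25000 nM as a limit as well. Compound 2 thus shares the limit of > 25000 nM in this assay, at which 3 of the 3 values shown sit, with both others and has no readable place among them.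

Compound 4 `O=C(/C=C/CNCCOc1ccc(Oc2c(-c3ccc(F)cc3)sc3cc(O)ccc23)cc1)N1CCCCC1` differs from compound 2 by 3-((piperidin-1-yl)carbonyl)prop-2-en-1-yl in place of (1-methylethenyl)carbonyl on an amine nitrogen in this one place. Among the compounds with values here, its new group resembles the one in compound 1, which carries 3-(methylcarbamoyl)prop-2-en-1-yl on an amine nitrogen in a ring. The measured steps offer little guidance: there is a step that the two limits leave unreadable from compound 1 to compound 2 and a step that the two limits leave unreadable from compound 1 to compound 3 and also a step that the two limits leave unreadable from compound 2 to compound 3 and none of them has a size. Within the data shown here, compound 1 and compound 2 both sit at the limit of > 25000 nM in this assay, at which 3 of the 3 values shown sit, so no step of readable size, in either direction, is expected in this assay for this change. The estimate therefore means a number no higher from compound 2 to compound 4 (the limit leaves the size open) as the expected step, with no clear direction. Compound 4 is estimated at 25000 nM in an expected range from 9000 nM to 60000 nM and may well be expected to end at a limit rather than a number.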

Compound 4, half-maximal inhibitory concentration: 16400 nM
Compound 4: middle estimate off by 1.5-fold (0.18 log units), on the high side, within the range that was stated.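

In this assay, putting 3-((piperidin-1-yl)carbonyl)prop-2-en-1-yl in place of (1-methylethenyl)carbonyl on the amine nitrogen gives an at least 1.5-fold lower number from compound 2 to compound 4 (0.18 log units; that floor lies within the scatter), so this position now has a step with a readable floor, though not a full size. Compound 2 itself remains a limit and not a number: the limit of > 25000 nM in this assay, at which 3 of the 4 values shown sit. Within the data shown here, the steps among compound 1, compound 2 and compound 3 cannot be read, so compound 4 gives the only number, and the floor of its step does not by itself show a change beyond the scatter.

Compound 1 differs from compound 4 in more than one place, so the compounds shown do not separate the part played by the piperidin-1-yl ring from that of the prop-2-en-1-yl chain or the change on the nitrogen. Going by these compounds, it also remains open whether a morpholin-4-yl ring or a dimethylamino group on that carbonyl, or a longer chain in place of prop-2-en-1-yl, would give a number in this assay.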